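Chain-End Hydroxyl on a Triazole Series in Pancreatic Cells

The source may report more compounds than this note shows. Statements on the series, on what has been measured and on what is new or still open speak of the compounds shown alone.

Among the compounds with values here, compound 1 `CCCCc1cn(C(c2ccccc2)c2cc3cc(Br)ccc3nc2OC)nn1` is one of three compounds measured in an ADME assay on PANC-1 cells (Homo sapiens) for cytotoxicity, read by sulforhodamine B assay, with a stated time of 48 h, tested at 10 uM (on this read-out higher numbers stand for more inhibition at the one concentration tested (going by the name of the read-out) and lower numbers for less inhibition), where compound 1 gives 5.46%. Its companions are compound 2 `CCOC(=O)c1cn(C(c2ccccc2)c2cc3cc(Br)ccc3nc2OC)nn1`, which in this assay gives 15.4%, and compound 3 `CCCCCc1cn(C(c2ccccc2)c2cc3cc(Br)ccc3nc2OC)nn1`, which gives 5.07%. Among these three numbers compound 1 stands second highest: its nearest neighbour is compound 3, with a number 0.4 percentage points lower from compound 1 to compound 3 (within the scatter), and its furthest is compound 2, with a number 9.9 percentage points higher from compound 1 to compound 2 (within the scatter). Within the data shown here, the only step that clears the scatter is a number 10.3 percentage points lower from compound 2 to compound 3 (beyond the scatter).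

Compound 4 `COc1nc2ccc(Br)cc2cc1C(c1ccccc1)n1cc(CCCCCO)nn1` is the next compound awaiting a number. It differs from compound 1 in one respect: hydroxymethyl in place of hydrogen on a saturated chain carbon, four bonds along the chain from an aromatic carbon. Among the measured compounds shown here, the step that bears most directly on this change is the one from compound 1 to compound 3, where the same chain was lengthened at the same carbon and the read-out in this assay barely moved. The hydroxymethyl group that enters brings a hydrogen-bond donor and acceptor, but nothing in the measured set tests such a group at this position, so there is no ground to expect a shift beyond the scatter in either direction. The step from compound 1 to compound 4 in this assay is therefore expected to be small, a number 1.5 percentage points higher from compound 1 to compound 4 (within the scatter). Compound 4 is estimated to give 7%, with a range from 0% to 18%.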

Compound 4, a percentage reported as inhibition, at one concentration (the size of the read-out at that concentration, not a potency): 19.6%
Beside the measured number, compound 4's estimate is 12.6 percentage points below it; the whole stated range lies below it.
By their numbers in this assay, from the lowest: compounds 3, 1, 2 and 4 (each within the scatter of the next, the first and the last beyond it).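

Within the data shown here, the chain on this aromatic carbon turns out to be a place where the read-out in this assay can move, although the step between the two plain alkyl chains, a number 0.4 percentage points lower from compound 1 to compound 3 (within the scatter), gave no sign of it: hydroxymethyl at the chain end gives a number 14.1 percentage points higher from compound 1 to compound 4 (beyond the scatter), and the hydroxy alone, in the one pair that differs by nothing else, gives a number 14.5 percentage points higher from compound 3 to compound 4 (beyond the scatter). The change therefore lies in the hydroxy at the chain end and not in the extra chain length, and the 5-hydroxypentyl group also reaches the level of the ethoxycarbonyl group, with a number 4.2 percentage points higher from compound 2 to compound 4 (within the scatter), so that these two compounds cannot be told apart here. Nothing available explains why the hydroxy at this place shifts the read-out.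

The compounds shown leave open whether the hydroxy must sit at the end of a chain of this length, as a 4-hydroxybutyl or a longer hydroxyalkyl chain would test. They also leave open whether an amine, a carboxylic acid or a methyl ether at the same chain end would give a similar number in this assay.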